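The source may report more compounds than this note shows. Statements on the series, on what has been measured and on what is new or still open speak of the compounds shown alone.

Four compounds share one sugar-bearing bicyclic core, and each carries a small aromatic group on a carbon of that core. Compound 1 `Nc1nc2c(c(-c3cccs3)cn2[C@@H]2O[C@H](CO)[C@@H](O)[C@H]2O)c(=O)[nH]1` and compound 3 `Nc1nc2c(c(-c3cc4ccccc4o3)cn2[C@@H]2O[C@H](CO)[C@@H](O)[C@H]2O)c(=O)[nH]1` have one kind of core, while compound 2 `CN(C)c1ncnc2c1c(-c1cccs1)cn2[C@@H]1O[C@H](CO)[C@@H](O)[C@H]1O` and compound 4 `CN(C)c1ncnc2c1c(-c1cc3ccccc3o1)cn2[C@@H]1O[C@H](CO)[C@@H](O)[C@H]1O` have another; the difference between the two cores is not broken down here.

In an ADME assay on BJ cells (Homo sapiens), read by MTT assay, with a stated time of 72 h (a lower number here means a stronger inhibitor, a higher number a weaker inhibitor), compound 1 gives only a limit, > 100000 nM. Compound 3 likewise gives only a limit in this assay, > 100000 nM. Compound 2 also reaches no number in this assay but only a limit, > 100000 nM.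

The change from compound 1 to compound 3 is 1-benzofuran-2-yl in place of thiophen-2-yl on an aromatic carbon. Among the measured compounds shown here, its step, a step that the two limits leave unreadable from compound 1 to compound 3, cannot be read, since both ends of it are limits rather than numbers; the limit of > 100000 nM in this assay, at which 3 of the 3 values shown sit, describes this situation, with every value so far resting at the same limit.

Compound 4 is not yet measured. It arises from compound 2 by the same change, (1-benzofuran-2-yl in place of thiophen-2-yl on an aromatic carbon), at the same place. From compound 2 to compound 4 the step expected is a step that the limit leaves unreadable from compound 2 to compound 4, and this expectation rests on compound 2 standing at its limit > 100000 nM and on compound 3 also standing at a limit > 100000 nM after the same change. Compound 4 is therefore estimated to sit at 200000 nM, within a range from 100000 nM to 1000000 nM, most likely reported as a limit.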

Compound 4, half-maximal inhibitory concentration: > 100000 nM
Compound 4: only a limit was reported; the forecaster's own chance of this, stated with the estimate: 85%; the middle value is on the limit's open side.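

Compound 2 and compound 4 each give only a limit, not a number, in this assay, so the step from thiophen-2-yl to 1-benzofuran-2-yl between them cannot be read: the limit of > 100000 nM in this assay, at which 4 of the 4 values shown sit.

The four compounds leave open whether the core or the aromatic group changes anything in this assay; none of them reaches an actual number there.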